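A few compounds are considered here, and "the series" means these few. Any claim that something is new, unique, unknown or untested is made for them only; others in the source may bear on it.

Going by the values given here, compound 3 `CCCCCCCCCCCCn1nnc(C(NC(=O)c2ccccc2[N+](=O)[O-])c2ccccc2)n1` gives 240 nM in an assay on microsomes from liver for inhibition of sterol O-acyltransferase 1 (Rattus norvegicus) (a lower number here means a stronger inhibitor, a higher number a weaker inhibitor), the lowest number among the three compounds measured so far. Compound 2 `CCCCCCCCCCCCn1nnc(C(NC(=O)c2ccc(C)cc2)c2ccccc2)n1` gives 510 nM in this assay, and compound 1 `CCCCCCCCCCCCn1nnc(C(NC(=O)c2c(C(C)C)cccc2C(C)C)c2ccccc2)n1` gives 810 nM. The step of a 3.4-fold lower number from compound 1 to compound 3 (0.53 log units; beyond the scatter) and the step of a 2.1-fold lower number from compound 2 to compound 3 (0.33 log units; beyond the scatter) both leave compound 3 standing apart, while a 1.6-fold lower number from compound 1 to compound 2 (0.20 log units; within the scatter) does not separate the other two.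

Compound 4 `CCCCCCCCCCCCn1nnc(C(NC(=O)c2ccc([N+](=O)[O-])cc2)c2ccccc2)n1` carries the change (4-nitrophenyl in place of 2-nitrophenyl on a carbonyl carbon). Among the compounds with values here, none of the measured steps moves the same group to another position on the ring; the nearest comparison is compound 1 against compound 2, where a 2,6-disubstituted phenyl gave way to a 4-substituted one and the step of a 1.6-fold lower number from compound 1 to compound 2 (0.20 log units; within the scatter) stayed within scatter. The two steps into compound 3 are modest, so the room for compound 4 to move is limited either way. In this assay compound 4 is therefore expected to show a 1.7-fold higher number from compound 3 to compound 4 (0.22 log units; within the scatter), no step beyond the scatter being predicted with confidence. The estimate for compound 4 is 400 nM, with a range from 150 nM to 1100 nM.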

Compound 4, half-maximal inhibitory concentration: 540 nM
Compound 4: the middle estimate sits 1.4-fold (0.13 log units) below what was measured; measured number inside the range.
By their numbers in this assay, from the lowest: compound 3; then compounds 2, 4 and 1 (each within the scatter of the next).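

In this assay, going by these compounds alone, moving the nitro group from 2-nitrophenyl to 4-nitrophenyl on the carbonyl carbon gives a step beyond the scatter (a 2.3-fold higher number from compound 3 to compound 4 (0.35 log units; beyond the scatter)), so with the same atoms and the same counts, the place of the group on the ring changes the reading, which no earlier step could show. Compound 4 stays within the scatter of the other two compounds (a 1.1-fold higher number from compound 2 to compound 4 (0.02 log units; within the scatter) with nitro in place of methyl, and a 1.5-fold lower number from compound 1 to compound 4 (0.18 log units; within the scatter) against the 2,6-diisopropylphenyl compound), so among these four compounds only the 2-nitrophenyl of compound 3 stands apart. Nothing measured here accounts for this difference between the two nitrophenyl compounds.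

From the compounds shown here alone, whether the lower number of compound 3 belongs to the nitro group itself or would also appear with another group in that place remains open. A 2-aminophenyl, 2-chlorophenyl or 2-carboxyphenyl on the same carbonyl carbon would separate these two readings.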